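The source may report more compounds than this note shows. Statements on the series, on what has been measured and on what is new or still open speak of the compounds shown alone.

The shared core in this series carries a saturated chain ending in an amine that bears an aryl group. Compound 1 `O=C(NCCCNc1nccc(-c2c(-c3cccc(F)c3)nc3sccn23)n1)c1ccc(F)cc1` holds a (4-fluorophenyl)carbonyl on that amine nitrogen, and in a functional assay on SK-MEL-28 cells (Homo sapiens) for cytotoxicity, read by MTT assay (on this read-out higher numbers stand for weaker inhibition and lower numbers for stronger inhibition), compound 1 gives > 20000 nM, which is a limit of the assay rather than a number. Compound 2 `O=S(=O)(NCCCNc1nccc(-c2c(-c3cccc(F)c3)nc3sccn23)n1)c1ccc(Cl)cc1` carries (4-chlorophenyl)sulfonyl in its place, and in this assay compound 2 gives 8450 nM. For the measured compounds named here, compound 2 thus stands as the only compound with a number, since compound 1 sits at the limit of > 20000 nM in this assay, at which 1 of the 2 values shown sits. Going by the values given here, the one measured step, an at least 2.3-fold lower number from compound 1 to compound 2 (0.37 log units; beyond the scatter), describes that replacement alone. Compound 3 `Cc1ccc(S(=O)(=O)NCCNc2nccc(-c3c(-c4cccc(F)c4)nc4sccn34)n2)cc1` differs from compound 2 by ((4-methylphenyl)sulfonyl)amino in place of (((4-chlorophenyl)sulfonyl)amino)methyl on a saturated chain carbon, two bonds along the chain from a nitrogen on an aromatic ring. Among the compounds with values here, no measured step covers the move from (((4-chlorophenyl)sulfonyl)amino)methyl to ((4-methylphenyl)sulfonyl)amino; the step of an at least 2.3-fold lower number from compound 1 to compound 2 (0.37 log units; beyond the scatter) concerns a different change and bears on it only indirectly, showing that a sulfonyl-bearing amine can reach a number in this assay. The expected step is therefore a 1.2-fold higher number from compound 2 to compound 3 (0.07 log units; within the scatter), close to the scatter. The estimate for compound 3 in this assay is 10000 nM, expected to fall between 3000 nM and 30000 nM.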

Compound 3, half-maximal inhibitory concentration: > 20000 nM
Compound 3: a limit, no number; the forecaster's own chance of this, stated with the estimate: 30%; at least 2.0-fold (0.30 log units) between middle value and limit.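

Compound 3 gives a limit and not a number in this assay, so it sits with compound 1 at the top of the range: the limit of > 20000 nM in this assay, at which 2 of the 3 values shown sit.

The replacement of (((4-chlorophenyl)sulfonyl)amino)methyl by ((4-methylphenyl)sulfonyl)amino gives an at least 2.3-fold higher number from compound 2 to compound 3 (0.37 log units; beyond the scatter), which shows that a sulfonyl on the amine nitrogen does not by itself yield a number in this assay. For the compounds shown here, the step between the two compounds that both sit at a limit cannot be read, so compound 2 remains the only compound with a number.

The change alters the chain and swaps chlorine on the aryl ring for methyl in a single move, and the compounds shown do not say which of the two accounts for the step. Still open, on these data alone, are what a (4-chlorophenyl)sulfonyl group would give on the chain of compound 3, what a (4-methylphenyl)sulfonyl group would give on the chain of compound 2, and whether a longer chain would bring a lower number than compound 2 gives.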